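Open-chain carbamate in place of the piperazine carbamate

This account rests on a few compounds, and the source may have more. Where it says the series, first, only, none or still open, it means among the compounds named here.

Two compounds in the series carry a measured number. In an assay on isolated protein for binding affinity to 5-hydroxytryptamine receptor 4 (Homo sapiens) (a lower number here means a stronger inhibitor, a higher number a weaker inhibitor), compound 1 `CS(=O)(=O)N1CCN(CC(O)CN2CCC(CNC(=O)c3cccc4[nH]cnc34)CC2)CC1` gives 6.31 nM, while compound 2 `COC(=O)N1CCN(CCN2CCC(CNC(=O)c3cccc4[nH]c(C(C)C)nc34)CC2)CC1` gives 1.59 nM. Compound 2 thus has the lowest of the two numbers, and the gap to compound 1 lies beyond the scatter of repeated measurements. Among the measured compounds shown here, the two differ in more than one place, so no single step between them is counted.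

Compound 3 `COC(=O)N(C)CC(O)CN1CCC(CNC(=O)c2cccc3[nH]c(C(C)C)nc23)CC1` is the next compound to be measured in this assay. It differs from compound 2 in one place: 1-hydroxy-2-((methoxycarbonyl)(methyl)amino)ethyl in place of (4-(methoxycarbonyl)piperazin-1-yl)methyl on a saturated chain carbon bound to an amine nitrogen in a ring. For the measured compounds named here, the ring that leaves and the chain that enters both carry a methoxycarbonyl group; the chain adds a hydroxyl, as the linker of compound 1 does, but no compound measured so far carries this open-chain arrangement, so the size of the step is uncertain. The expectation is a modest rise in the number, a 2.5-fold higher number from compound 2 to compound 3 (0.40 log units; beyond the scatter), not far beyond the scatter. Compound 3 is estimated at 4 nM, with a range from 1.2 nM to 13 nM.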

Compound 3, inhibition constant: 3.98 nM
Estimate against measurement, compound 3: 1.0-fold (0.00 log units) above; the range from low to high includes it.
By their numbers in this assay, from the lowest: compound 2; then compounds 3 and 1 (each within the scatter of the next).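

Working notes on the linker position: in this assay, the step of a 2.5-fold higher number from compound 2 to compound 3 (0.40 log units; beyond the scatter) is the first reading at this position, on a saturated chain carbon bound to an amine nitrogen in a ring, and it is modest, though beyond the scatter. Compound 3 still gives 3.98 nM without the six-membered ring of the (4-(methoxycarbonyl)piperazin-1-yl)methyl group, so within this pair the ring is not needed for a low nanomolar reading, at a modest cost. The change combines three things, namely loss of the ring, loss of one ring nitrogen and gain of a hydroxyl with its hydrogen-bond donor, and nothing here bears on which of them accounts for the step.

The pair cannot separate the hydroxyl from the ring opening, so the same open chain without its hydroxyl would be the most direct next reading. Also open, as far as these compounds go, is how this position responds to a longer chain, or to a free amine or a carboxylic acid in place of the methoxycarbonyl group.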